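Working notes on the carbonyl tail of the shared core

The source may hold more compounds than are shown below. What is called first, only, known or untested is meant among the compounds shown, and "the series" means these compounds.

Measured compounds in a functional assay on isolated protein for inhibition of Glucose-dependent insulinotropic receptor (Rattus norvegicus), read by HTRF and cAMP accumulation; on this read-out higher numbers stand for larger maximal responses and lower numbers for smaller maximal responses:
compound 1 `Cc1nc(S(C)(=O)=O)ccc1Oc1ncnc(OC2CCN(C(=O)OC(C)C)CC2)c1F`: 77%
compound 2 `Cc1nc(S(C)(=O)=O)ccc1Oc1ncnc(OC2CCN(C(=O)OC(C)(C)C(F)(F)F)CC2)c1F`: 79%
compound 3 `Cc1nc(S(C)(=O)=O)ccc1Oc1ncnc(OC2CCN(C(=O)OC(C)(C)C#N)CC2)c1F`: 97%

Compound 3 gives the highest efficacy of the three measured compounds; its nearest neighbour is compound 2 and its furthest is compound 1, and both steps up to compound 3 lie beyond the scatter. Compound 4 `Cc1nc(S(C)(=O)=O)ccc1Oc1ncnc(OC2CCN(C(=O)SC(C)C)CC2)c1F` is not yet measured. It differs from compound 3 in one place: isopropylsulfanyl in place of 1-cyano-1-methylethoxy on a carbonyl carbon.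

Bearing on this change are a number 20 percentage points higher from compound 1 to compound 3 (beyond the scatter) and a number 18 percentage points higher from compound 2 to compound 3 (beyond the scatter), both modest and beyond the scatter, which show that cyano on the saturated chain carbon raised efficacy. a number 2 percentage points higher from compound 1 to compound 2 (within the scatter) shows that trifluoromethyl in place of hydrogen on that carbon made no difference beyond the scatter. For the measured compounds named here, the step to compound 4 removes the cyano and at the same time exchanges the oxygen for a sulfur on the carbonyl carbon; the sulfur-for-oxygen exchange has no measured counterpart. The expectation rests on a number 20 percentage points higher from compound 1 to compound 3 (beyond the scatter) being undone: a modest fall, a number 17 percentage points lower from compound 3 to compound 4 (beyond the scatter), is expected, back toward the level of compound 1. The range is kept wide. Compound 4 is therefore estimated at 80% in this assay, range 65% to 95%.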

Compound 4, largest response reached (reported as efficacy), in percent of the reference or control that the assay uses: 81%
Compound 4: middle estimate off by 1 percentage points, on the low side; the measured number falls inside the stated range.
By their numbers in this assay, from the lowest: compounds 1, 2 and 4 (each within the scatter of the next); then compound 3.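

In this assay, for the compounds shown here, the new result gives the first reading of sulfur for oxygen at this carbonyl carbon, with isopropylsulfanyl in place of isopropoxy giving a number 4 percentage points higher from compound 1 to compound 4 (within the scatter) and so no difference beyond the scatter for this exchange on its own. Isopropylsulfanyl in place of 1-methyl-1-(trifluoromethyl)ethoxy gives a number 2 percentage points higher from compound 2 to compound 4 (within the scatter) and in place of 1-cyano-1-methylethoxy gives a number 16 percentage points lower from compound 3 to compound 4 (beyond the scatter), which leaves compounds 1, 2 and 4 together and compound 3 alone above them, so that among these four groups on the carbonyl carbon only 1-cyano-1-methylethoxy stands apart. No independent data on hand explain either the flat sulfur-for-oxygen exchange or the separate standing of the nitrile-bearing group.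

Still open, from the compounds shown here alone, is whether a 1-cyano-1-methylethylsulfanyl group on the same carbonyl carbon would read with compound 3 or with compound 4 in this assay, which would show whether the nitrile keeps its step when sulfur replaces the oxygen. Also open, going by these compounds, is how an isopropylamino group or a plain butyl chain on this carbonyl carbon would read against these four compounds.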